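Methoxy for Methyl: Expected Shift in a Mouse Assay

This account rests on a few compounds, and the source may have more. Where it says the series, first, only, none or still open, it means among the compounds named here.

Measured compounds:
compound 1 `COc1ccc(Nc2nnc(Nc3nc(-c4ccc(Br)cc4)cs3)s2)cc1`: 79.4 mg/kg
compound 2 `Cc1ccc(Nc2nnc(Nc3nc(-c4ccc([N+](=O)[O-])cc4)cs3)s2)cc1`: 232 mg/kg

Both compounds were tested in a functional assay on the whole organism (strain albino) with Mus musculus as the target; on this read-out higher numbers stand for an effect only at larger amounts of compound and lower numbers for an effect already at smaller amounts. Compound 2 stands highest of the two numbers; its nearest neighbour is compound 1, whose value lies lower by a gap beyond the usual scatter, so compound 1 acts at smaller amounts than compound 2.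

Compound 3 `COc1ccc(Nc2nnc(Nc3nc(-c4ccc([N+](=O)[O-])cc4)cs3)s2)cc1` has not yet been measured. It differs from compound 2 in one place: methoxy in place of methyl on an aromatic carbon. Going by the values given here, no pair of measured compounds shows this exact change on its own. Compound 1 does carry a methoxy group at the same place, but it also differs from compound 2 at the other end of the molecule, so its lower number cannot be credited to the methoxy group alone. The expectation is therefore cautious: a small step toward a lower number from compound 2 to compound 3, of a size a 1.5-fold lower number from compound 2 to compound 3 (0.16 log units; within the scatter), which may well sit within the scatter. On that basis compound 3 is estimated at 160 mg/kg, with a likely range from 60 mg/kg to 400 mg/kg.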

Compound 3, dose for half-maximal effect: 433 mg/kg
The estimate for compound 3 lay 2.7-fold (0.43 log units) below the measured number; measured number outside the range, above it.
By their numbers in this assay, from the lowest: compound 1; then compounds 2 and 3 (each within the scatter of the next).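

In this assay, going by these compounds alone, methoxy in place of methyl, para to a large group, gives a 1.9-fold higher number from compound 2 to compound 3 (0.27 log units; within the scatter) and so, seen alone for the first time, this exchange cannot be told apart from the ordinary variation between repeat measurements. With the methoxy group held fixed, nitro in place of bromo on an aromatic carbon gives a 5.5-fold higher number from compound 1 to compound 3 (0.74 log units; beyond the scatter) and is therefore the only single change among these compounds with a step larger than that variation. Nothing shown here bears on why either step has the size it does.

It remains open whether methoxy and methyl would also read alike with bromo in place of nitro, since compound 1 has no methyl partner among these compounds. Also open, on these data alone, is how an amine or a longer chain at the methoxy position, or a carboxylic acid in place of nitro, would read in this assay on this same core.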